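Amide aryl swap: hydroxyphenyl to nitrophenyl on a shared core

The compounds below may be only part of what the source reports. "The series", "measured", "known", "first", "only" and "open" are said of these compounds alone.

Measured compounds, with their values in a functional assay on MDA-MB-231 cells (Homo sapiens) for cytotoxicity, read by MTT assay; a lower number here means a stronger inhibitor, a higher number a weaker inhibitor:
compound 1 `CCn1cc(-c2nc3ccc([N+](=O)[O-])cc3o2)c(=O)c2cc(F)c(N3CCNC(C)C3)c(F)c21`: 2000 nM
compound 2 `CCn1cc(C(=O)Nc2ccccc2)c(=O)c2cc(F)c(N3CCNC(C)C3)c(F)c21`: 7400 nM
compound 3 `CCn1cc(C(=O)Nc2ccccc2O)c(=O)c2cc(F)c(N3CCNC(C)C3)c(F)c21`: 7430 nM

Compound 3 gives the highest number of the three, but compound 2 sits within the scatter of it, so no order between those two can be read; compound 1 lies well below, and the gap from compound 3 to compound 1 is beyond the scatter. Among the compounds with values here, the only single-point step in hand, a 1.0-fold higher number from compound 2 to compound 3 (0.00 log units; within the scatter), moved nothing beyond the scatter.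

Compound 4 `CCn1cc(C(=O)Nc2cccc([N+](=O)[O-])c2)c(=O)c2cc(F)c(N3CCNC(C)C3)c(F)c21` differs from compound 3 by 3-nitrophenyl in place of 2-hydroxyphenyl on an amide-type nitrogen. Within the data shown here, no measured step places a nitro group on the amide aryl ring. Compound 1 carries a nitro group elsewhere in the molecule and gives 2000 nM, yet it differs from compound 3 in more than one place and is read only as a value, not as a step. The step from compound 2 to compound 3 shows that a substituent on this ring can be added without any change. For compound 4 a modest step toward a lower number is expected, with wide uncertainty, a 1.5-fold lower number from compound 3 to compound 4 (0.17 log units; within the scatter). Compound 4 is estimated at 5000 nM, in the range 1500 nM to 15000 nM.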

Compound 4, half-maximal inhibitory concentration: 3250 nM
Estimate against measurement, compound 4: 1.5-fold (0.19 log units) above; the range from low to high includes it.
By their numbers in this assay, from the lowest: compounds 1 and 4 (each within the scatter of the next); then compounds 2 and 3 (each within the scatter of the next).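

In this assay, the amide aryl ring now shows a response to substitution: a 2.3-fold lower number from compound 2 to compound 4 (0.36 log units; beyond the scatter) with nitro in place of hydrogen, whereas hydroxy in place of hydrogen gave a 1.0-fold higher number from compound 2 to compound 3 (0.00 log units; within the scatter), which stays within the scatter. Replacing 2-hydroxyphenyl with 3-nitrophenyl on the amide-type nitrogen gives a 2.3-fold lower number from compound 3 to compound 4 (0.36 log units; beyond the scatter), so the two substituted rings do not read alike at this position, although the shift is modest in size. Nothing available bears on why the number moves with this change.

The compounds shown do not separate the identity of the substituent from its place on the ring, as the hydroxy and nitro groups stand at differently numbered ring positions in 2-hydroxyphenyl and 3-nitrophenyl. Going by these compounds, it also remains open how an amine or a carboxylic acid on this aryl ring would read in this assay, and so whether the lower number is particular to the nitro group.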